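Cytotoxicity of Two Analogs and One New Compound

The source may hold more compounds than are shown below. What is called first, only, known or untested is meant among the compounds shown, and "the series" means these compounds.

Compound 1 `N#CCCCn1c(Cn2c(=O)n(-c3ncccn3)c3ccncc32)cc2cc(Cl)ccc21` was tested in an ADME assay on HeLa cells (Homo sapiens) for cytotoxicity, read by ATP content, with a stated time of 3 days (a higher number here means that more compound is tolerated, a lower number that less compound is tolerated), and there compound 1 gives > 50000 nM, which is a limit of the assay rather than a number. Compound 2 `CC1(n2c(=O)n(Cc3cc4cc(Cl)ccc4n3CCCS(C)(=O)=O)c3cnccc32)CC1` was tested the same way; in this assay compound 2 gives > 50000 nM, again a limit of the assay and not a number. Going by the values given here, both measured values therefore rest at the limit of > 50000 nM in this assay, at which 2 of the 2 values shown sit, so no step between measured compounds can be drawn from them, and compound 1 stands at that limit with nothing beside it to order it against. Compound 3 `N#CCCCn1c(Cn2c(=O)n(-c3ccc(OC(F)(F)F)cc3)c3ccncc32)cc2cc(Cl)ccc21` differs from compound 1 in one place: 4-(trifluoromethoxy)phenyl in place of pyrimidin-2-yl on an aromatic nitrogen. With both measured compounds sitting at the same limit, the account expects no step beyond the scatter, the change being estimated as a number no higher from compound 1 to compound 3 (the limit leaves the size open). Compound 3 is accordingly expected to give about 50000 nM in this assay, within a range from 20000 nM to 100000 nM.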

Compound 3, half-maximal cytotoxic concentration: > 50000 nM
Compound 3 ended at the assay's limit; the forecaster's own chance of this, stated with the estimate: 75%; the middle value sits exactly at the limit.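

In this assay compound 3 gives > 50000 nM as a limit of the assay, not a number. No step can be read from compound 1 to compound 3, since all the values shown share one limit: the limit of > 50000 nM in this assay, at which 3 of the 3 values shown sit. The compounds shown leave open at what concentration any of them becomes cytotoxic, and how they would rank.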